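The source may hold more compounds than are shown below. What is called first, only, known or untested is meant among the compounds shown, and "the series" means these compounds.

Within the data shown here, in an assay on BAF cells for inhibition of ribosomal protein S6 kinase alpha-2 (Mus musculus) (a higher number here means a weaker inhibitor, a lower number a stronger inhibitor), compound 3 `COc1ccccc1-c1cccc2nc(Nc3cc(OC)c(OC)c(OC)c3)oc12` gives 5700 nM, the only number among the three measured values. Compound 1 `COc1cccc(F)c1-c1cccc2nc(Nc3ccccc3)oc12` sits at a limit in this assay, > 20000 nM. Compound 2 `COc1cccc(F)c1-c1cccc2nc(Nc3cccc(S(N)(=O)=O)c3)oc12` likewise sits at a limit, > 20000 nM. The step that the two limits leave unreadable from compound 1 to compound 2 cannot be read in size because both compounds sit at the limit of > 20000 nM in this assay, at which 2 of the 3 values shown sit. Compound 4 `COc1cc(Nc2nc3cccc(-c4ccccc4-c4cn[nH]c4)c3o2)cc(OC)c1OC` differs from compound 3 by 1H-pyrazol-4-yl in place of methoxy on an aromatic carbon. No measured step covers this change, and the single measured step is unreadable, so nothing among the shown values points in either direction. Compound 4 is therefore expected to lie close to compound 3, with a step of a 1.9-fold lower number from compound 3 to compound 4 (0.28 log units; within the scatter) that need not exceed the scatter. The estimated value for compound 4 in this assay is 3000 nM, ranging from 800 nM to 12000 nM.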

Compound 4, half-maximal inhibitory concentration: > 20000 nM
Compound 4 gave a limit, no number; the forecaster's own chance of this, stated with the estimate: 15%; at least 6.6-fold (0.82 log units) between middle value and limit.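

In this assay, among these compounds, the swap to 1H-pyrazol-4-yl in place of methoxy, ortho to a large group, gives an at least 3.5-fold higher number from compound 3 to compound 4 (0.54 log units; beyond the scatter) as the only readable step here, the earlier step being unreadable. It shows that this position is not indifferent to substitution and that this larger ring goes with a weaker result than methoxy. Compound 4 gives a limit and not a number, so the full size of the loss stays unknown: the limit of > 20000 nM in this assay, at which 3 of the 4 values shown sit.

On these data alone, whether a hydroxyl group or a methyl group at this place would keep or improve on the value of compound 3 stays open. So does whether an amine would be tolerated there.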